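The compounds below may be only part of what the source reports. "The series", "measured", "known", "first", "only" and "open" are said of these compounds alone.

Compound 1 `O=C(Nn1c(-c2cccc([N+](=O)[O-])c2)nc2c(-c3ccc(Cl)cc3)n[nH]c2c1=O)c1cccnc1` in a functional assay on SK-MEL-2 cells (Homo sapiens) for cytotoxicity, read by sulforhodamine B assay, with a stated time of 2 days, tested at 100 uM (on this read-out higher numbers stand for more inhibition at the one concentration tested (going by the name of the read-out) and lower numbers for less inhibition), gives 16.3%.
Compound 2 `O=C(Nn1c(-c2cccc([N+](=O)[O-])c2)nc2c(-c3ccco3)n[nH]c2c1=O)c1cccnc1` in this assay gives 19.2%.

Compound 2 holds the higher figure of the two, though the step of a number 2.9 percentage points higher from compound 1 to compound 2 (within the scatter) lies within the usual scatter, so the two compounds cannot be told apart on these numbers. That single step concerns the aryl group on the shared core, furan-2-yl in place of 4-chlorophenyl, and it barely moved the read-out.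

Compound 3 `COc1cccc(-c2nc3c(-c4ccco4)n[nH]c3c(=O)n2NC(=O)c2cccnc2)c1` is the next compound to be measured. It differs from compound 2 only on the other aryl ring: methoxy in place of nitro on an aromatic carbon. Within the data shown here, no measured step touches this position, so nothing among the data speaks for or against a change. Among the measured compounds shown here, the only step seen so far was small, and the expectation for compound 3 is therefore a step of a number 0.2 percentage points lower from compound 2 to compound 3 (within the scatter) in this assay, no larger than the scatter. Compound 3 is thus estimated at 19%, within a range of 5% to 35%.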

Compound 3, a percentage reported as inhibition, at one concentration (the size of the read-out at that concentration, not a potency): 34.1%
For compound 3 the middle estimate is 15.1 percentage points below the measured one, within the range that was stated.
By their numbers in this assay, from the lowest: compounds 1 and 2 (each within the scatter of the next); then compound 3.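

On the six-membered aromatic ring of the shared core's aryl group, 3-methoxyphenyl in place of 3-nitrophenyl gives a number 14.9 percentage points higher from compound 2 to compound 3 (beyond the scatter) in this assay. Among these compounds, this is the first change to move the read-out by more than the scatter, so this position can affect how much inhibition appears at the one concentration tested, whereas the earlier swap of 4-chlorophenyl for furan-2-yl could not be told apart from noise. Nothing measured here gives a reason for this step.

On these data alone, a single pair cannot show whether the gain comes from losing the nitro or from gaining the methoxy, and how an amine or a hydroxyl group would read in the same place remains open. As far as these compounds go, it is also open whether the same swap would give a similar step with 4-chlorophenyl in place of furan-2-yl.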